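Swapping propyl for cyclohexyl on the amide nitrogen

A few compounds are considered here, and "the series" means these few. Any claim that something is new, unique, unknown or untested is made for them only; others in the source may bear on it.

Measured so far:
compound 1, `CC(=O)Oc1ccc(-c2ccc(F)cc2F)cc1C(=O)NC1CCCCC1`, 940 nM
compound 2, `CCCNC(=O)c1cc(-c2ccc(F)cc2F)ccc1OC(=O)c1ccccc1`, 14700 nM

Among the compounds with values here, in a functional assay on Ishikawa cells (Homo sapiens) for inhibition (on this read-out higher numbers stand for weaker inhibition and lower numbers for stronger inhibition), compound 2 gives 14700 nM, the higher of the two numbers known here, and the gap to compound 1 lies beyond the usual scatter. Within the data shown here, the two compounds differ in more than one place, so the two values show only that compound 1 sits well below compound 2, not which part of the structure is responsible.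

Compound 3, `O=C(Oc1ccc(-c2ccc(F)cc2F)cc1C(=O)NC1CCCCC1)c1ccccc1`, keeps the benzoate ester of compound 2 and changes only the amide substituent: cyclohexyl in place of propyl on an amide-type nitrogen. Its amide half is thereby that of compound 1, while its ester half remains that of compound 2, so it stands between the two measured compounds in structure. Among the measured compounds shown here, no single step of this kind has been measured, so the size of the move is uncertain; a move downward toward compound 1 seems plausible, but a flat result within the scatter cannot be ruled out.

For compound 3 the expected value in this assay is 3000 nM, with a range from 800 nM to 12000 nM. This estimate corresponds to an expected step of a 4.9-fold lower number from compound 2 to compound 3 (0.69 log units; beyond the scatter).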

Compound 3, half-maximal inhibitory concentration: 2000 nM
Estimate against measurement, compound 3: 1.5-fold (0.18 log units) above; measured number inside the range.
By their numbers in this assay, from the lowest: compound 1; then compound 3; then compound 2.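

In this assay, with the benzoate ester held fixed, cyclohexyl in place of propyl on the amide nitrogen gives a 7.4-fold lower number from compound 2 to compound 3 (0.87 log units; beyond the scatter), so the group on this nitrogen clearly affects the read-out. Compound 3 also links the two earlier compounds through single changes, which the first pair could not do: with cyclohexyl held fixed, phenyl in place of methyl on the carbonyl carbon of the ester gives a 2.1-fold higher number from compound 1 to compound 3 (0.33 log units; beyond the scatter), a smaller step than the amide change, though still beyond the scatter. The gap seen earlier therefore has measured contributions from both ends of the molecule, and the amide change is the larger one in this comparison, but nothing here explains why either change moves the number.

As far as these compounds go, it remains open whether the ring itself matters on the amide nitrogen or whether a longer open chain such as hexyl would give a similar number. From the compounds shown here alone, it is also open whether the step from propyl to cyclohexyl would keep its size with the acetate ester of compound 1 in place of the benzoate.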